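From 1-methylheptyl to nonyl on a shared core

The source may report more compounds than this note shows. Statements on the series, on what has been measured and on what is new or still open speak of the compounds shown alone.

Measured in an ADME assay on Vero cells (Chlorocebus sabaeus) for cytotoxicity, read by reporter gene assay, with a stated time of 4 days; a lower number here means a stronger inhibitor, a higher number a weaker inhibitor:
Compound 1 `CCCC(C)C(=O)NCC(C)(C)CC1=C(O)C(=O)c2ccccc2C1=O`: 48100 nM
Compound 2 `CCCCCCC(C)C(=O)NCC(C)(C)CC1=C(O)C(=O)c2ccccc2C1=O`: 15500 nM

Of these two compounds, compound 2 has the lower number, and the gap between them is a 3.1-fold lower number from compound 1 to compound 2 (0.49 log units; beyond the scatter). Compound 3 `CCCCCCCCCC(=O)NCC(C)(C)CC1=C(O)C(=O)c2ccccc2C1=O` is the next to be read. It differs from compound 2 by nonyl in place of 1-methylheptyl on a carbonyl carbon. For the measured compounds named here, only one measured step bears on this change, the modest one from compound 1, and it is a different kind of change. Going by the values given here, no measured pair shows what replacing 1-methylheptyl with nonyl does. A small drop or no step beyond the scatter is therefore expected in this assay. The expected step is a 1.3-fold lower number from compound 2 to compound 3 (0.11 log units; within the scatter). Compound 3 is estimated at 12000 nM, with an expected range of 5000 nM to 30000 nM.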

Compound 3, half-maximal inhibitory concentration: 15000 nM
Compound 3: the middle estimate sits 1.3-fold (0.10 log units) below what was measured, and the stated range covers the measured number.
By their numbers in this assay, from the lowest: compounds 3 and 2 (each within the scatter of the next); then compound 1.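

In this assay, nonyl in place of 1-methylheptyl on the carbonyl carbon gives a 1.0-fold lower number from compound 2 to compound 3 (0.01 log units; within the scatter), so compound 2 and compound 3 cannot be told apart, and at this place the straight chain reads the same as the branched one. Nonyl in place of 1-methylbutyl gives a 3.2-fold lower number from compound 1 to compound 3 (0.51 log units; beyond the scatter), so compound 3, like compound 2, stands clear of compound 1, which shows that this separation does not depend on keeping the branch. Nothing available explains these numbers.

On these data alone, whether a longer chain than nonyl on the same carbonyl carbon would separate from compound 2 and compound 3 remains open. Also open, as far as these compounds go, is how a chain ending in an amine or a carboxylic acid would read at this place.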